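Amide variation at the carbonyl carbon: compound 2 to compound 3

A few compounds are considered here, and "the series" means these few. Any claim that something is new, unique, unknown or untested is made for them only; others in the source may bear on it.

Measured so far:
- compound 1, `CN1CCN(c2ccc(Nc3nc(-c4cccc(NC(=O)c5ccccc5F)c4)sc3C(N)=O)cc2)CC1`: 97.3%
- compound 2, `CN1CCN(c2ccc(Nc3nc(-c4cccc(NC(=O)c5ccc(C(F)(F)F)cn5)c4)sc3C(N)=O)cc2)CC1`: 84.6%

In a functional assay on Raji cells (Homo sapiens) for antiproliferative activity, read by CCK-8 assay, with a stated time of 72 h, tested at 40 uM (on this read-out lower numbers stand for less inhibition and higher numbers for more inhibition at the one concentration tested (going by the name of the read-out)), compound 1 gives 97.3%, and compound 2 gives 84.6%. Compound 2 stands as the lower of the two numbers; its nearest neighbour is compound 1, and the step of a number 12.7 percentage points lower from compound 1 to compound 2 (beyond the scatter) separates them.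

The next compound is compound 3, `CN1CCN(c2ccc(Nc3nc(-c4cccc(NC(=O)[C@H]5CC[C@H](C)CC5)c4)sc3C(N)=O)cc2)CC1`. The change from compound 2 is 4-methylcyclohexyl in place of 5-(trifluoromethyl)pyridin-2-yl on a carbonyl carbon. Going by the values given here, the only measured step that touches the same position is a number 12.7 percentage points lower from compound 1 to compound 2 (beyond the scatter), where one aromatic group replaced another on the carbonyl carbon and the read-out fell modestly. Among the compounds with values here, no measured pair shows an aromatic group giving way to a non-aromatic ring at that position, so the step from compound 2 to compound 3 has no direct precedent; the single step at this carbonyl carbon suggests the read-out is sensitive there.

Compound 3 is therefore expected to land near the present numbers or somewhat lower, an estimated a number 6.6 percentage points lower from compound 2 to compound 3 (within the scatter). The estimate for compound 3 is 78%, with a range from 55% to 95%.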

Compound 3, a percentage reported as inhibition, at one concentration (the size of the read-out at that concentration, not a potency): 22.4%
Estimate against measurement, compound 3: 55.6 percentage points above; the measured number lies below the stated range.
By their numbers in this assay, from the lowest: compound 3; then compound 2; then compound 1.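

In this assay the change from an aromatic ring to 4-methylcyclohexyl on the carbonyl carbon gives a number 62.2 percentage points lower from compound 2 to compound 3 (beyond the scatter) and, starting from the 2-fluorophenyl amide, gives a number 74.9 percentage points lower from compound 1 to compound 3 (beyond the scatter) as well. Both steps are much larger than a number 12.7 percentage points lower from compound 1 to compound 2 (beyond the scatter) where one aromatic ring replaced another, so among these three compounds the exchange of aromatic rings costs far less than the move to the carbon-only non-aromatic ring. The position is therefore more than mildly sensitive: compound 3 gives 22.4% in this assay and sits beyond the scatter from both compound 1 and compound 2, the lowest of the three at the one concentration tested.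

On these data alone, the step changes several things at once, including the aromatic ring, the ring nitrogen, the trifluoromethyl group and the added methyl, so it remains open whether an unsubstituted cyclohexyl, a piperidine ring carrying a basic amine, or a plain phenyl would read like compound 1 and compound 2 or like compound 3. No measurement available here bears on why the read-out falls at this change.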